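Replacing Butoxy with Cyclopentylamino on the Shared Core

The source may hold more compounds than are shown below. What is called first, only, known or untested is meant among the compounds shown, and "the series" means these compounds.

- compound 1 (`C=C[C@]1(C)CC[C@@H](C(=C)Cn2ccnc2)C[C@H]1C(=C)C`) gives 15700 nM
- compound 2 (`C=C[C@]1(C)CC[C@@H](C(=C)COCCCC)C[C@H]1C(=C)C`) gives 266000 nM

In a functional assay on HeLa cells (Homo sapiens) for antiproliferative activity, read by WST assay, with a stated time of 24 h (on this read-out higher numbers stand for weaker inhibition and lower numbers for stronger inhibition), compound 2 holds the higher of the two numbers (266000 nM), which means the weaker inhibition. Within the data shown here, only one measured step bears on the next change (a 17-fold higher number from compound 1 to compound 2 (1.23 log units; beyond the scatter)). That step is large, and it brought butoxy in place of 1H-imidazol-1-yl on a saturated chain carbon bound to a double-bonded chain carbon.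

Compound 3 (`C=C[C@]1(C)CC[C@@H](C(=C)CNC2CCCC2)C[C@H]1C(=C)C`) is altered at that same place (cyclopentylamino in place of butoxy on a saturated chain carbon bound to a double-bonded chain carbon), with cyclopentylamino in place of butoxy. Here butoxy leaves again, so the number may move back towards that of compound 1 (15700 nM), which has no butoxy at this place. Yet cyclopentylamino is not 1H-imidazol-1-yl, and one step is thin evidence, so only a partial return seems reasonable. Among the measured compounds shown here, what is expected is a clear move to a lower number (a 6.7-fold lower number from compound 2 to compound 3 (0.82 log units; beyond the scatter)), though smaller than the one step measured so far. The estimated value for compound 3 is 40000 nM (expected range 12000 nM to 130000 nM).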

Compound 3, half-maximal inhibitory concentration: 520 nM
Estimate against measurement, compound 3: 77-fold (1.89 log units) above; the measured number lies below the stated range.
By their numbers in this assay, from the lowest: compound 3; then compound 1; then compound 2.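

In this assay, cyclopentylamino in place of butoxy on a saturated chain carbon bound to a double-bonded chain carbon gives a 510-fold lower number from compound 2 to compound 3 (2.71 log units; beyond the scatter), a step larger than the one that had brought butoxy into this place and one that shows this place can carry far stronger inhibition than the first two compounds suggested. The change does more than undo the loss seen with butoxy, since cyclopentylamino in place of 1H-imidazol-1-yl gives a 30-fold lower number from compound 1 to compound 3 (1.48 log units; beyond the scatter), which puts compound 3 lowest of the three and shows that 1H-imidazol-1-yl did not mark the best level reachable at this place. No evidence is available to account for the size of either step.

Cyclopentylamino differs from butoxy both in its nitrogen and in its five-membered ring, so the compounds shown do not separate these two features, a question that butylamino and cyclopentyloxy at this place would address. They also leave open how the number would respond to a larger ring on the nitrogen, as in cyclohexylamino, or to a nitrogen held within the ring, as in piperidin-1-yl.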